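Swapping a Methoxy for a Chloro on Compound 3

The source may hold more compounds than are shown below. What is called first, only, known or untested is meant among the compounds shown, and "the series" means these compounds.

- Compound 1 `Cc1[nH]c2ccc(Cl)cc2c(=O)c1Br` gives 2.02 as its reading
- Compound 2 `Cc1[nH]c2cc(Cl)ccc2c(=O)c1-c1ccccc1` gives 2.18 as its reading
- Compound 3 `COc1ccc2nc(C)c(Cc3ccccc3)c(OC)c2c1` gives 4.2 as its reading

Among the measured compounds shown here, all three readings come from a physicochemical assay for lipophilicity, at pH 7.4 (a lower number here means a more polar compound, a higher number a more lipophilic compound), and are the only measurements available so far. Compound 1 and compound 2 lie within the usual scatter of each other. Compound 3 stands highest of the three, and its gap to each of the other two lies well beyond the scatter.

The next compound to be measured is compound 4 `COc1c(Cc2ccccc2)c(C)nc2ccc(Cl)cc12` and it departs from compound 3 at a single place. The change is chloro in place of methoxy on an aromatic carbon and in plain terms it puts chloro in place of methoxy on an aromatic carbon. For the measured compounds named here, the second methoxy position of compound 3 has no counterpart in this change, since only one group leaves and one enters.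

Going by the values given here, no measured pair shows this swap, so the expectation rests on the structural change alone, with compound 3 at 4.2 as the starting point. The expected step of a number 0.50 log units higher from compound 3 to compound 4 (beyond the scatter) is a moderate rise in this assay that would probably lie beyond the scatter, though the data cannot confirm this. Compound 4 is estimated at 4.7 with an expected range from 4.2 to 5.2 on this reading.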

Compound 4, distribution coefficient: 4.93
For compound 4 the middle estimate is 0.23 log units below the measured one, and the stated range covers the measured number.
By their numbers in this assay, from the lowest: compounds 1 and 2 (each within the scatter of the next); then compound 3; then compound 4.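

In this assay, among the compounds shown here, the exchange on this aromatic carbon, meta to a fused ring and para to a fused ring, gives a number 0.73 log units higher from compound 3 to compound 4 (beyond the scatter) and is the first single-place change available. It shows that the reading responds to what sits at this position, and that chloro in place of methoxy moves it by more than repeated measurements would. The change takes away a methoxy of two heavy atoms with one hydrogen-bond acceptor and brings in a chloro of one heavy atom with none, but nothing measured here accounts for the rise, which stands as an observation on this one pair.

The compounds shown leave open how an amine, a carboxylic acid or a longer chain such as ethoxy would read on this same aromatic carbon; chloro is the only replacement for methoxy seen here. They also leave open whether the same swap would give a step of similar size at the methoxy group that compound 4 keeps, or on a core carrying other groups.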